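This account rests on a few compounds, and the source may have more. Where it says the series, first, only, none or still open, it means among the compounds named here.

Measured so far in a functional assay (aorta) with Rattus norvegicus as the target; on this read-out higher numbers stand for an effect only at larger amounts of compound and lower numbers for an effect already at smaller amounts:
- Compound 1 `NCC(=O)Nc1cc2cc[nH]c(=O)c2cc1Cl`: 2500 nM
- Compound 2 `CC(C)[C@H](N)C(=O)Nc1cc2cc[nH]c(=O)c2cc1Cl`: 500 nM

Of these two, compound 2 holds the lower number, at 500 nM. Compound 3 `N[C@H]1CC[C@@H](C(=O)Nc2cc3cc[nH]c(=O)c3cc2Cl)CC1` has not yet been measured. It keeps the shared core and the amide link but differs from compound 2 in one place: 4-aminocyclohexyl in place of 1-amino-2-methylpropyl on a carbonyl carbon. In words, 4-aminocyclohexyl stands in place of 1-amino-2-methylpropyl on a carbonyl carbon.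

For the measured compounds named here, only one measured step bears on this change, a 5.0-fold lower number from compound 1 to compound 2 (0.70 log units; beyond the scatter). It is modest, and it arose when isopropyl took the place of hydrogen on the saturated chain carbon of the same group. That step offers only indirect guidance, since neither measured compound carries a ring in this group and a single step shows no trend. Therefore, no step clearly beyond the scatter is expected in this assay, with a slight lean towards a lower number. The expected change is a 1.7-fold lower number from compound 2 to compound 3 (0.22 log units; within the scatter). For compound 3 the estimated value is 300 nM, with an expected range from 60 nM to 1500 nM.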

Compound 3, half-maximal effective concentration: 180 nM
Compound 3: middle estimate off by 1.7-fold (0.22 log units), on the high side, and the stated range covers the measured number.
By their numbers in this assay, from the lowest: compound 3; then compound 2; then compound 1.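

In this assay, the step to 4-aminocyclohexyl on the carbonyl carbon gives (a 2.8-fold lower number from compound 2 to compound 3 (0.44 log units; beyond the scatter)), showing that a group with a six-membered carbon ring, absent from both earlier compounds, is compatible with a lower number than the open-chain 1-amino-2-methylpropyl. Measured against the aminomethyl group, the same ring gives a large step (a 14-fold lower number from compound 1 to compound 3 (1.14 log units; beyond the scatter)), so across these three compounds the number falls each time the group on the carbonyl carbon grows, and none of them goes against this order. Nothing available explains why the number falls with these changes.

The step from compound 2 to compound 3 changes the ring, the size of the group and the defined stereocentres together, so these compounds do not separate the contribution of the ring from that of the other two changes. On these data alone, it also remains open how a plain cyclohexyl without the amine, the other stereoisomer of 4-aminocyclohexyl, a piperidine ring or a longer aminoalkyl chain would behave at this place.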